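The compounds below may be only part of what the source reports. "The series", "measured", "known", "first", "only" and "open" are said of these compounds alone.

For the measured compounds named here, only two compounds have been measured so far. In an ADME assay on Vero cells (Chlorocebus sabaeus) for cytotoxicity, read by MTT assay, with a stated time of 72 h (a higher number here means a weaker inhibitor, a lower number a stronger inhibitor), compound 1 `CC(C)[S+]([O-])CCCCN=C=S` gives 10400 nM and compound 2 `[O-][S+](CCCN=C=S)Cc1ccccc1` gives 10100 nM. These two values lie within the usual scatter of repeated measurements, so compound 2 stands level with compound 1, and neither can be called the more cytotoxic.

The next compound, compound 3 `[O-][S+](CCCCCCN=C=S)Cc1ccccc1`, has not yet been measured. It is made from compound 2 by one structural change: a group of 6 heavy atoms (4 carbon, 1 nitrogen, 1 sulfur; no ring) in place of a group of 3 heavy atoms (1 carbon, 1 nitrogen, 1 sulfur; no ring), on a saturated chain carbon, three bonds along the chain from a sulfur. This change sits on a saturated chain carbon, three bonds along the chain from a sulfur.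

Going by the values given here, no measured pair of compounds shows a step at this place, so the data give no direct guide to its size. Starting from compound 2 at 10100 nM, a modest move towards a lower number in this assay is expected, and it may not clear the scatter by much. The expected change is a 1.6-fold lower number from compound 2 to compound 3 (0.19 log units; within the scatter). For compound 3 the estimated value is 6500 nM, with an expected range from 2500 nM to 14000 nM.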

Compound 3, half-maximal inhibitory concentration: 4330 nM
Estimate against measurement, compound 3: 1.5-fold (0.18 log units) above; measured number inside the range.
By their numbers in this assay, from the lowest: compound 3; then compounds 2 and 1 (each within the scatter of the next).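

In this assay, putting a group of 6 heavy atoms (4 carbon, 1 nitrogen, 1 sulfur; no ring) in place of a group of 3 heavy atoms (1 carbon, 1 nitrogen, 1 sulfur; no ring), on a saturated chain carbon, three bonds along the chain from a sulfur, gives a 2.3-fold lower number from compound 2 to compound 3 (0.37 log units; beyond the scatter), a step that is modest in size but beyond the scatter. The two compounds measured earlier stood level and could not show whether any single change moves this number, whereas this pair shows that the read-out does respond to a change at this position, and that the response here is towards a lower number. Why it moves in this direction cannot be said, as nothing available here bears on the cause of this step.

A single step cannot show whether the number would keep falling with a longer chain or would level off or turn back. It also leaves open how a different end group at this place, such as an amine or a carboxylic acid, would compare with the group in compound 3.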